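This account rests on a few compounds, and the source may have more. Where it says the series, first, only, none or still open, it means among the compounds named here.

Measured so far in a functional assay on U-937 cells (Homo sapiens) for antiproliferative activity, read by MTT assay, with a stated time of 72 h; a lower number here means a stronger inhibitor, a higher number a weaker inhibitor:

- compound 1, `Cc1ccc(-c2noc(CCCCCCC(=O)Nc3ccccc3N)n2)cc1`: 460 nM
- compound 2, `Nc1ccccc1NC(=O)CCCCCCc1nc(-c2ccc(C(F)(F)F)cc2)no1`: 5280 nM
- compound 3, `Nc1ccccc1NC(=O)CCCCCCc1nc(-c2ccccc2Cl)no1`: 6910 nM

Compound 3 gives the highest number of the three. Its nearest neighbour is compound 2, and the step of a 1.3-fold higher number from compound 2 to compound 3 (0.12 log units; within the scatter) lies within the scatter, so the two cannot be ordered. The step of a 15-fold higher number from compound 1 to compound 3 (1.18 log units; beyond the scatter) and the step of an 11-fold higher number from compound 1 to compound 2 (1.06 log units; beyond the scatter) are both large and beyond the scatter; compound 1 stands apart from the other two.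

Compound 4, `Nc1ccccc1NC(=O)CCCCCCc1nc(-c2cccc([N+](=O)[O-])c2)no1`, has not been measured. It differs from compound 3 in this way: 3-nitrophenyl in place of 2-chlorophenyl on an aromatic carbon. Only the aryl substitution changes bear on this step. Both of them move away from compound 1, and both known non-methyl aryl groups sit close together at the weak end. Going by the values given here, no measured step touches the new group itself, so the direction of any change is unknown; the expectation is a step of no more than the scatter, a 1.5-fold lower number from compound 3 to compound 4 (0.19 log units; within the scatter), with a wide range on either side. The estimate for compound 4 in this assay is 4500 nM, between 1500 nM and 14000 nM.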

Compound 4, half-maximal inhibitory concentration: 2150 nM
Compound 4: the middle estimate sits 2.1-fold (0.32 log units) above what was measured; measured number inside the range.
By their numbers in this assay, from the lowest: compound 1; then compound 4; then compounds 2 and 3 (each within the scatter of the next).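

In this assay, going by these compounds alone, the aryl group on the ring carbon between two ring nitrogen atoms is less uniform than the earlier compounds suggested: the change to 3-nitrophenyl gives a 3.2-fold lower number from compound 3 to compound 4 (0.51 log units; beyond the scatter) and a 2.5-fold lower number from compound 2 to compound 4 (0.39 log units; beyond the scatter), so not every aryl group other than 4-methylphenyl falls at the weak end. The same group still does not match 4-methylphenyl, with a 4.7-fold higher number from compound 1 to compound 4 (0.67 log units; beyond the scatter), which leaves compound 4 in a middle place among the four. Nothing at hand bears on the reason for this ordering.

The four aryl groups differ both in the substituent and in where it sits, so the compounds shown cannot separate these two changes. Open questions are how unsubstituted phenyl, 3-methylphenyl and 4-nitrophenyl would rank at this position, and whether 3-aminophenyl would stay near 3-nitrophenyl.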